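Removing the methyl from a methoxy group: an expected loss

A few compounds are considered here, and "the series" means these few. Any claim that something is new, unique, unknown or untested is made for them only; others in the source may bear on it.

Compound 1 `O=C(Nc1cccc(-n2cc(-c3ccncc3)c(-c3ccc(Cl)c(O)c3)n2)c1)Nc1cccc(C(F)(F)F)c1` gives 1340 nM in a functional assay on RPMI-8226 cells (Homo sapiens) for inhibition, read by sulforhodamine B assay, with a stated time of 48 h; a lower number here means a stronger inhibitor, a higher number a weaker inhibitor.
Compound 2 `COc1cc(-c2nn(-c3cccc(NC(=O)Nc4cc(C(F)(F)F)cc(C(F)(F)F)c4)c3)cc2-c2ccncc2)ccc1Cl` gives 310 nM in this assay.
Compound 3 `COc1cc(-c2nn(-c3cccc(NC(=O)Nc4cccc(C(F)(F)F)c4)c3)cc2-c2ccncc2)ccc1Cl` gives 340 nM in this assay.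

Among these three, compound 2 gives the smallest number, yet it cannot be told apart from compound 3, and only compound 1 lies clearly above it. Compound 4 `O=C(Nc1cccc(-n2cc(-c3ccncc3)c(-c3ccc(Cl)c(O)c3)n2)c1)Nc1cc(C(F)(F)F)cc(C(F)(F)F)c1` differs from compound 2 by hydrogen in place of methyl on an oxygen on an aromatic ring. The step that bears on this is the reverse one: a 3.9-fold lower number from compound 1 to compound 3 (0.60 log units; beyond the scatter). Taking the methyl away should undo that gain. The step of a 1.1-fold higher number from compound 2 to compound 3 (0.04 log units; within the scatter) shows the second trifluoromethyl changes little, so compound 4 should land close to compound 1. The number for compound 4 is therefore expected to rise, a 4.0-fold higher number from compound 2 to compound 4 (0.61 log units; beyond the scatter), to an estimated 1250 nM, within a range of 500 nM to 3000 nM.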

Compound 4, half-maximal inhibitory concentration: 480 nM
For compound 4 the middle estimate is 2.6-fold (0.42 log units) above the measured one; measured number outside the range, below it.
By their numbers in this assay, from the lowest: compounds 2, 3 and 4 (each within the scatter of the next); then compound 1.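

With the second trifluoromethyl present, changing methoxy to hydroxy gives a 1.5-fold higher number from compound 2 to compound 4 (0.19 log units; within the scatter), so the loss seen with one trifluoromethyl does not clearly appear here. Adding that second trifluoromethyl to the hydroxy compound gives a 2.8-fold lower number from compound 1 to compound 4 (0.45 log units; beyond the scatter), a change beyond the scatter that was not seen with methoxy. Even so, neither change can be said to differ between the two cores: the same change on two cores in this assay, a 3.9-fold lower number (0.60 log units; beyond the scatter) from compound 1 to compound 3 and a 1.5-fold lower number (0.19 log units; within the scatter) from compound 4 to compound 2, 2.5-fold (0.41 log units) apart, within the scatter of two such steps Likewise for the trifluoromethyl change: the same change on two cores in this assay, a 1.1-fold higher number (0.04 log units; within the scatter) from compound 2 to compound 3 and a 2.8-fold higher number (0.45 log units; beyond the scatter) from compound 4 to compound 1, 2.5-fold (0.41 log units) apart, within the scatter of two such steps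

The compounds shown leave open how an ethoxy group or an amine in place of the methoxy would compare.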